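Extending the saturated chain of compound 3

The source may hold more compounds than are shown below. What is called first, only, known or untested is meant among the compounds shown, and "the series" means these compounds.

Measured in a functional assay on LoVo cells (Homo sapiens) for inhibition, read by MTT assay, with a stated time of 48 h; on this read-out lower numbers stand for stronger inhibition and higher numbers for weaker inhibition:
Compound 1 `COc1ccc(N(C)c2nc(C)nc3ccccc23)cc1C(=O)OCCC[Se]C#N`: 854 nM
Compound 2 `COc1ccc(N(C)c2nc(C)nc3ccccc23)cc1C(=O)NCC[Se]C#N`: 561 nM
Compound 3 `COc1ccc(N(C)c2nc(C)nc3ccccc23)cc1C(=O)OCCCC[Se]C#N`: 1080 nM

The three values sit close together. Repeat measurements of a single compound also vary, and each gap here lies within that scatter. Compound 3, at 1080 nM, is therefore not clearly separated from the other two: the data show a 1.3-fold higher number from compound 1 to compound 3 (0.10 log units; within the scatter) and a 1.9-fold higher number from compound 2 to compound 3 (0.28 log units; within the scatter).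

The next compound to be measured is compound 4 `COc1ccc(N(C)c2nc(C)nc3ccccc23)cc1C(=O)OCCCCC[Se]C#N`. Its difference from compound 3 is a group of 4 heavy atoms (2 carbon, 1 nitrogen, 1 selenium; no ring) in place of a group of 3 heavy atoms (1 carbon, 1 nitrogen, 1 selenium; no ring), on a saturated chain carbon, four bonds along the chain from an oxygen next to a carbonyl group. The rest of the molecule stays the same.

For the measured compounds named here, the closest precedent is a change of the same kind, made one position earlier on the chain: a 1.3-fold higher number from compound 1 to compound 3 (0.10 log units; within the scatter). The other two steps, a 1.5-fold lower number from compound 1 to compound 2 (0.18 log units; within the scatter) and a 1.9-fold higher number from compound 2 to compound 3 (0.28 log units; within the scatter), alter the group on the carbonyl carbon more broadly, so they bear on this question less directly. Going by the values given here, with only one close precedent, and that one within the scatter, no real shift can be predicted in this assay. The expected result is a 1.1-fold higher number from compound 3 to compound 4 (0.05 log units; within the scatter), which would not go beyond the scatter. For compound 4 the estimated value is 1200 nM, with an expected range from 600 nM to 2400 nM.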

Compound 4, half-maximal inhibitory concentration: 714 nM
The estimate for compound 4 lay 1.7-fold (0.23 log units) above the measured number; low and high end bracket the measured number.
By their numbers in this assay, from the lowest: compounds 2, 4, 1 and 3 (each within the scatter of the next).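

In this assay, the longer chain of compound 4 gives no clear change at this saturated chain carbon, four bonds along the chain from an oxygen next to a carbonyl group (a 1.5-fold lower number from compound 3 to compound 4 (0.18 log units; within the scatter)), so this chain can be extended further without a step that leaves the scatter. The same holds for its comparisons with the shortest ester, a 1.2-fold lower number from compound 1 to compound 4 (0.08 log units; within the scatter), and with the amide, a 1.3-fold higher number from compound 2 to compound 4 (0.10 log units; within the scatter), so among these four compounds neither chain length nor the swap between ester and amide separates the values. Nothing given here explains why the values sit so close together.

The compounds shown leave open whether a still longer chain, or a chain carrying a ring, would finally produce a step beyond the scatter, and whether an amide with a longer chain would behave as the esters do. Every compound shown also keeps selenium and the nitrile at the chain end, so the effect of sulfur in place of selenium, or of an amine or a carboxylic acid at that end, remains unknown.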